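This account rests on a few compounds, and the source may have more. Where it says the series, first, only, none or still open, it means among the compounds named here.

Measured so far:
compound 1 `CNc1ncccc1C(=O)N/N=C/c1ccccc1` — 47.2%
compound 2 `CNc1ncccc1C(=O)N/N=C/c1cccc(Cl)c1` — 61.7%

In a functional assay on the whole organism (strain Wistar) for inhibition, with Rattus norvegicus as the target, read by paw edema, with a stated time of 2 h, at a dose of 10 mg/kg by the intraperitoneal route (on this read-out lower numbers stand for less inhibition and higher numbers for more inhibition at the one dose given (going by the name of the read-out)), compound 1 gives 47.2%, the lower of the two numbers; compound 2 gives 61.7%. Within the data shown here, the single step in hand is a number 14.5 percentage points higher from compound 1 to compound 2 (beyond the scatter).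

Compound 3 `CNc1ncccc1C(=O)N/N=C/c1ccc(Cl)cc1` differs from compound 1 in one place: chloro in place of hydrogen on an aromatic carbon. Among the measured compounds shown here, the only comparable step is the one from compound 1 to compound 2, which also brings chloro onto the same ring and raised the read-out by a modest margin. A rise of similar size is therefore expected for compound 3, an estimated a number 12.8 percentage points higher from compound 1 to compound 3 (beyond the scatter). Compound 3 is estimated at 60%, expected to lie between 48% and 72%.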

Compound 3, a percentage reported as inhibition, in the whole organism at one dose (the size of the read-out at that dose, not a potency): 54.1%
The estimate for compound 3 lay 5.9 percentage points above the measured number; measured number inside the range.
By their numbers in this assay, from the lowest: compounds 1, 3 and 2 (each within the scatter of the next, the first and the last beyond it).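

In this assay, chloro para to a large group gives a number 6.9 percentage points higher from compound 1 to compound 3 (within the scatter) and so does not separate from the parent at this position, whereas a number 14.5 percentage points higher from compound 1 to compound 2 (beyond the scatter) does separate for the chloro of compound 2. Even so, compound 3 and compound 2 lie within the scatter of each other, so the two chloro placements cannot be told apart. No supporting data bear on this result. Open, on these data alone, is whether methoxy, an amine or a carboxylic acid at this same position would move the read-out beyond the scatter from compound 1.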